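From 4-methylphenyl to 1-phenylethyl on an Amine Nitrogen

The source may hold more compounds than are shown below. What is called first, only, known or untested is meant among the compounds shown, and "the series" means these compounds.

Compound 1 `CCCn1c(=O)[nH]c2nc(-c3ccc(S(=O)(=O)N4CCN(c5ccccc5C)CC4)cc3)[nH]c2c1=O` gives 25%.
Compound 2 `CCCn1c(=O)[nH]c2nc(-c3ccc(S(=O)(=O)N4CCN(c5ccc(C)cc5)CC4)cc3)[nH]c2c1=O` gives 25%.

Both values come from an assay on CHO cells for displacement of a labelled ligand from adenosine receptor A3 (Homo sapiens), read by scintillation counting, with a stated time of 45 min, tested at 1 uM, in the presence of a further agent that is not named here; on this read-out higher numbers stand for more inhibition at the one concentration tested (going by the name of the read-out) and lower numbers for less inhibition. Compound 2 stands level with compound 1 at the digits shown: the step of no change at the digits printed from compound 1 to compound 2 (within the scatter) lies within the scatter, so moving the methyl from one spot of the ring to another on the amine nitrogen in a ring left the read-out where it was.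

Compound 3 `CCCn1c(=O)[nH]c2nc(-c3ccc(S(=O)(=O)N4CCN(C(C)c5ccccc5)CC4)cc3)[nH]c2c1=O` has not yet been measured. It differs from compound 2 in one place: 1-phenylethyl in place of 4-methylphenyl on an amine nitrogen in a ring. The ring on the amine nitrogen is no longer joined directly; it now hangs from a short chain that also carries a methyl.

Going by the values given here, only one measured step is available, and it concerns a change within the aromatic ring rather than the link to the nitrogen, so it gives little direct guidance. With nothing shown that moves the read-out, the expectation for compound 3 is a step of no change at the digits printed from compound 2 to compound 3 (within the scatter) of no size beyond the scatter. Compound 3 is estimated at 25%, within 5% to 45%.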

Compound 3, a percentage reported as inhibition, at one concentration (the size of the read-out at that concentration, not a potency): 0%
Estimate against measurement, compound 3: 25 percentage points above; the measured number lies below the stated range.
By their numbers in this assay, from the lowest: compound 3; then compounds 1 and 2 (each within the scatter of the next).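

In this assay, this position on the amine nitrogen in a ring does respond to change: 1-phenylethyl gives a number 25 percentage points lower from compound 2 to compound 3 (beyond the scatter), and the same group gives a number 25 percentage points lower from compound 1 to compound 3 (beyond the scatter). Moving the methyl around the ring had shown no such thing, with no change at the digits printed from compound 1 to compound 2 (within the scatter), so the new result suggests that how the ring is attached to the nitrogen matters more here than where the methyl sits on it, at least among these three compounds. No supporting data bear on the reason for this drop.

The change also brings in two features at once, a carbon between the ring and the nitrogen and a methyl on that carbon, so benzyl, which has the carbon without the methyl, and 2-phenylethyl, a longer chain, would be needed to tell which feature goes with the lower number. Each compound is also described at only one concentration, so these numbers leave open how the compounds differ in potency.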